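Swapping 4-methoxyphenyl for 3-chlorophenyl on the amide nitrogen

The source may report more compounds than this note shows. Statements on the series, on what has been measured and on what is new or still open speak of the compounds shown alone.

In a functional assay on HT-29 cells (Homo sapiens) for antiproliferative activity, read by sulforhodamine B assay, with a stated time of 72 h (on this read-out lower numbers stand for stronger inhibition and higher numbers for weaker inhibition), compound 2 (`O=C(Cn1nc(Cc2ccccc2)c2ccccc2c1=O)Nc1ccccc1`) gives 95400 nM. Compound 1 (`COc1ccc(NC(=O)Cn2nc(-c3ccccc3)c3ccccc3c2=O)cc1`) gives only a limit, > 100000000 nM. Compound 3 (`COc1ccc(NC(=O)Cn2nc(Cc3ccccc3)c3ccccc3c2=O)cc1`) also gives only a limit, > 100000000 nM, and so stands at the limit of > 100000000 nM in this assay, at which 2 of the 3 values shown sit.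

Compound 4 (`O=C(Cn1nc(Cc2ccccc2)c2ccccc2c1=O)Nc1cccc(Cl)c1`) follows from compound 3 by 3-chlorophenyl in place of 4-methoxyphenyl on an amide-type nitrogen. The step that bears on this is the large one for methoxy in place of hydrogen on an aromatic carbon, an at least 1000-fold higher number from compound 2 to compound 3 (3.02 log units; beyond the scatter). The other step, a step that the two limits leave unreadable from compound 1 to compound 3, gives no size. Compound 4 carries no methoxy, like compound 2, so a large fall in the number is expected, an at least 1600-fold lower number from compound 3 to compound 4 (3.22 log units; beyond the scatter). The estimate for compound 4 is 60000 nM, with an expected range of 15000 nM to 250000 nM.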

Compound 4, half-maximal inhibitory concentration: 3680 nM
Beside the measured number, compound 4's estimate is 16-fold (1.21 log units) above it; the whole stated range lies above it.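

On the amide nitrogen, 3-chlorophenyl in place of 4-methoxyphenyl gives an at least 27000-fold lower number from compound 3 to compound 4 (4.43 log units; beyond the scatter) in this assay, a size that rests on a limit for compound 3, not on a number. Chloro in place of hydrogen gives a 26-fold lower number from compound 2 to compound 4 (1.41 log units; beyond the scatter). The earlier compounds shown here showed only a rise in the number at this phenyl, with methoxy, whereas this step shows that a substituent there can also lower it.

Whether the fall belongs to chloro itself or to its place stays open, as 4-chlorophenyl and 3-methoxyphenyl are not among the compounds shown. Also open, as far as these compounds go, is how an amine or a carboxylic acid on this phenyl would read.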